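From phenyl to 4-methoxyphenyl: an expected modest step

This account rests on a few compounds, and the source may have more. Where it says the series, first, only, none or still open, it means among the compounds named here.

Among the compounds with values here, in a functional assay on CCRF-CEM cells (Homo sapiens) for antiproliferative activity (on this read-out lower numbers stand for stronger inhibition and higher numbers for weaker inhibition), compound 1 (`COc1cc(C(=O)c2sc(-c3ccccc3)cc2N)cc(OC)c1OC`) gives 4.5 nM and stands lowest among the three compounds measured so far. Compound 2 (`COc1cccc(-c2cc(N)c(C(=O)c3cc(OC)c(OC)c(OC)c3)s2)c1`) gives 16 nM and compound 3 (`COc1cc(C(=O)c2sc(-c3ccc(C)cc3)cc2N)cc(OC)c1OC`) gives 15 nM in the same read-out. Compound 4 (`COc1ccc(-c2cc(N)c(C(=O)c3cc(OC)c(OC)c(OC)c3)s2)cc1`) awaits measurement. Its difference from compound 1 is methoxy in place of hydrogen on an aromatic carbon and amounts to methoxy in place of hydrogen on an aromatic carbon, which turns phenyl into 4-methoxyphenyl.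

Within the data shown here, two measured steps bear on this change. The closest in kind is a 3.6-fold higher number from compound 1 to compound 2 (0.55 log units; beyond the scatter) (modest) where compound 2 carries the same added methoxy as 3-methoxyphenyl. The other is a 3.3-fold higher number from compound 1 to compound 3 (0.52 log units; beyond the scatter) (modest) where compound 3 carries methyl as 4-methylphenyl. Between those two products the step of a 1.1-fold lower number from compound 2 to compound 3 (0.03 log units; within the scatter) lies within the scatter. Among the measured compounds shown here, both substitutions of the phenyl of compound 1 thus raised the number by a similar modest amount, and no measured compound goes against this, though only two such steps exist. A similar modest rise is therefore expected for the new methoxy, with the estimated step being a 3.1-fold higher number from compound 1 to compound 4 (0.49 log units; beyond the scatter) in this assay for now. For compound 4 the estimated value is 14 nM with an expected range from 5 nM to 45 nM at this stage.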

Compound 4, half-maximal inhibitory concentration: 19 nM
For compound 4 the middle estimate is 1.4-fold (0.13 log units) below the measured one; the measured number falls inside the stated range.
By their numbers in this assay, from the lowest: compound 1; then compounds 3, 2 and 4 (each within the scatter of the next).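

In this assay, methoxy placed para to a large group gives a 4.2-fold higher number from compound 1 to compound 4 (0.63 log units; beyond the scatter), so the rise seen with 3-methoxyphenyl and 4-methylphenyl also appears with 4-methoxyphenyl, and none of the substituted compounds shown goes against it. The place of the methoxy makes no difference that can be read here, as 4-methoxyphenyl in place of 3-methoxyphenyl gives a 1.2-fold higher number from compound 2 to compound 4 (0.07 log units; within the scatter) and this step lies within the scatter. The identity of the added group at the para place is equally unresolved between methyl and methoxy, since the exchange gives a 1.3-fold higher number from compound 3 to compound 4 (0.10 log units; within the scatter), also within the scatter, and all three substituted compounds therefore form one group above the unsubstituted phenyl of compound 1.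

No evidence is at hand to explain this shared rise. The compounds shown leave open whether an amine or a carboxylic acid on this aromatic carbon would give a similar rise, and whether a longer chain such as ethoxy or butoxy would raise the number further or leave it within the scatter of compound 4.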